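Chlorophenyl placement on the shared core

This account rests on a few compounds, and the source may have more. Where it says the series, first, only, none or still open, it means among the compounds named here.

Compound 2 `Oc1ccc(-c2cc(-c3cccs3)nc(-c3ccccc3Cl)c2)cc1` carries a thiophen-2-yl group and a 2-chlorophenyl group on the shared core; in a functional assay on T47D cells (Homo sapiens) for cytotoxicity, read by CCK-8 assay and cell counting, with a stated time of 2 days (on this read-out higher numbers stand for weaker inhibition and lower numbers for stronger inhibition), compound 2 gives 5870 nM. Compound 3 `Oc1ccc(-c2cc(-c3ccco3)nc(-c3ccccc3Cl)c2)cc1` differs only in the furan-2-yl group, and compound 3 gives 5480 nM. The step of a 1.1-fold lower number from compound 2 to compound 3 (0.03 log units; within the scatter) leaves the two within the scatter of each other, so no order between them is claimed. Compound 1 `Oc1ccc(-c2cc(-c3ccccn3)nc(-c3ccccc3Cl)c2)cc1` carries a pyridin-2-yl group instead, and compound 1 gives "not determined" (no result reported), so nothing is known for it.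

Compound 4 `Oc1ccc(-c2cc(-c3ccc(Cl)cc3)nc(-c3cccs3)c2)cc1` follows from compound 2 through (4-chlorophenyl in place of 2-chlorophenyl on an aromatic carbon). Going by the values given here, no measured step touches the chlorophenyl group; the one available step concerns the five-membered ring only and is within the scatter. There is therefore no basis for expecting a shift in this assay beyond the scatter in either direction, and the uncertainty is wide.

For compound 4 the expected step is a 1.2-fold lower number from compound 2 to compound 4 (0.07 log units; within the scatter). Compound 4 is estimated at 5000 nM, with a range from 1500 nM to 16000 nM.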

Compound 4, half-maximal inhibitory concentration: 6450 nM
Compound 4: middle estimate off by 1.3-fold (0.11 log units), on the low side; low and high end bracket the measured number.
By their numbers in this assay, from the lowest: compounds 3, 2 and 4 (each within the scatter of the next).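

On the aromatic carbon next to the ring nitrogen, 4-chlorophenyl in place of 2-chlorophenyl gives, in this assay, a 1.1-fold higher number from compound 2 to compound 4 (0.04 log units; within the scatter), so this exchange of the two chlorophenyl groups leaves the read-out within the scatter. Going by these compounds alone, the earlier step changed only the five-membered ring, whereas this one is the first reading on the chlorophenyl group, and for this pair the two isomeric groups cannot be told apart. No measurement is available to bear on why the two numbers stay together.

On these data alone, it remains open whether a group other than chlorophenyl at this carbon, such as an aminophenyl or carboxyphenyl group, would move the number beyond the scatter. Whether 3-chlorophenyl would fall with the two isomers shown is also open.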